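The source may report more compounds than this note shows. Statements on the series, on what has been measured and on what is new or still open speak of the compounds shown alone.

Three stereoisomers of one dipeptide-like scaffold have been measured in an ADME assay on the whole organism (Mus musculus, strain C57BL/6) for pharmacokinetics, read by HPLC, with a stated time of 6 h, at a dose of 25 mg/kg by the oral route; on this read-out higher numbers stand for higher exposure at the dose given and lower numbers for lower exposure. Compound 1 `O=C(O)[C@@H](CO)NC(=O)[C@H]1C[C@H](O)CN1` gives 22900 nM. Compound 2 `O=C(N[C@H](CO)C(=O)O)[C@@H]1C[C@H](O)CN1` gives 22200 nM. Compound 3 `O=C(O)[C@H](CO)NC(=O)[C@H]1C[C@@H](O)CN1` gives 22700 nM. The steps among them are small: a 1.0-fold lower number from compound 1 to compound 2 (0.01 log units; within the scatter), a 1.0-fold lower number from compound 1 to compound 3 (0.00 log units; within the scatter) and a 1.0-fold higher number from compound 2 to compound 3 (0.01 log units; within the scatter). In each case the two compounds differ only in configuration as drawn, as shown by the fact that compounds 1 and 2 differ only in the configuration as drawn, the fact that compounds 1 and 3 differ only in the configuration as drawn and (the fact that compounds 2 and 3 differ only in the configuration as drawn), and none of the three steps leaves the scatter. Compound 2 therefore stands with the lowest number of the three, but its distance to compound 3 and to compound 1 is within the scatter, so no order can be read among them.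

Compound 4 `O=C(O)[C@H](CO)NC(=O)[C@@H]1C[C@H](O)CN1` is the fourth stereoisomer and has not yet been measured in this assay. Relative to compound 2 the change is the two compounds have the same atoms and bonds and differ only in configuration as drawn: 1 of 3 stereo elements differ; a stereocentre at a saturated chain carbon is drawn R in compound 2 and S in compound 4. Within the data shown here, the steps that bear on this are the three stereochemical steps already measured, every one of which inverted at least one stereocentre of the same scaffold without moving the number beyond the scatter. On that basis the author expects a 1.0-fold higher number from compound 2 to compound 4 (0.01 log units; within the scatter), with no change beyond the scatter in either direction. Compound 4 is estimated to reach 22500 nM in this assay, within a range from 14000 nM to 36000 nM.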

Compound 4, maximal plasma concentration: 1050 nM
For compound 4 the middle estimate is 21-fold (1.33 log units) above the measured one, and the stated range ends above it.
By their numbers in this assay, from the lowest: compound 4; then compounds 2, 3 and 1 (each within the scatter of the next).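

Inverting only the stereocentre at the saturated chain carbon gives a 21-fold lower number from compound 2 to compound 4 (1.33 log units; beyond the scatter) in this assay, so configuration alone, with no atom or bond changed, can carry a large step on this scaffold: the fact that compounds 2 and 4 differ only in the configuration as drawn. Compound 4 stands apart from the other two stereoisomers as well, with a 22-fold lower number from compound 3 to compound 4 (1.33 log units; beyond the scatter) and a 22-fold lower number from compound 1 to compound 4 (1.34 log units; beyond the scatter), though each of these two steps also inverts a stereocentre at a saturated ring carbon. The S drawing at the chain carbon is not enough by itself, as compound 3 carries it too and gives 22700 nM; among these four compounds, the low number appears only where that drawing meets the ring configuration of compound 4, a dependence that the earlier steps, all within the scatter, could not show.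

The maximal plasma concentration alone does not tell whether the low number of compound 4 arises during uptake or during removal from the plasma. The compounds shown also leave open whether this sensitivity to configuration would persist with a methyl group in place of the hydroxymethyl group, or with a methyl ester in place of the carboxylic acid.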